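Pyridyl ureas: swapping the pyridine attachment point

A few compounds are considered here, and "the series" means these few. Any claim that something is new, unique, unknown or untested is made for them only; others in the source may bear on it.

Measured in a physicochemical assay for lipophilicity, read by HPLC, measured as octanol-water partition, at pH 7.2; a higher number here means a more lipophilic compound, a lower number a more polar compound:
compound 1 `O=C(Nc1ccc(F)c(C(F)(F)F)c1)Nc1ccccn1`: 3.7
compound 2 `O=C(Nc1cnccn1)Nc1cnccn1`: 0.8
compound 3 `O=C(Nc1ccc(C(=O)O)cc1)Nc1ccc(F)c(C(F)(F)F)c1`: 1.5

Among these three, compound 1 reads highest in this assay; compound 3 stands nearest to it and compound 2 furthest, and both gaps lie beyond the usual scatter. For the measured compounds named here, no pair of measured compounds differs in a single place, so no measured step is available to guide the next move.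

Compound 4 `O=C(Nc1ccncc1)Nc1ccc(F)c(C(F)(F)F)c1` is not yet measured in this assay. It differs from compound 1 only as follows:

pyridin-4-yl in place of pyridin-2-yl on an amide-type nitrogen

The pyridin-2-yl ring leaves and a pyridin-4-yl ring enters on the amide-type nitrogen, the rest of compound 1 being kept. Nothing among the three measured compounds isolates this change, so the direction rests on the structural change alone. A step downward from compound 1 to compound 4, estimated at a number 0.70 log units lower from compound 1 to compound 4 (beyond the scatter), is expected, somewhat beyond the scatter rather than within it. For compound 4 the expected value in this assay is 3, with a range of 2.3 to 3.6.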

Compound 4, distribution coefficient: 3.2
Compound 4: middle estimate off by 0.20 log units, on the low side; the range from low to high includes it.
By their numbers in this assay, from the lowest: compound 2; then compound 3; then compound 4; then compound 1.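

In this assay the series now has its first single-place step, a modest one: a number 0.50 log units lower from compound 1 to compound 4 (beyond the scatter) with pyridin-4-yl in place of pyridin-2-yl on an amide-type nitrogen. The two compounds hold the same atoms joined differently, so at this position the attachment point of the ring alone is enough to move the reading beyond the scatter. Nothing on hand explains the direction or the size of this step.

Still open, from the compounds shown here alone, is where pyridin-3-yl would fall on this amide-type nitrogen, and whether an amine or a methoxy group on the pyridine ring would change the reading further. Equally open, going by these compounds, is whether the same swap gives a similar step on a core other than that of compound 1.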